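From Compound 2 to Compound 4 in Cells

The source may report more compounds than this note shows. Statements on the series, on what has been measured and on what is new or still open speak of the compounds shown alone.

Measured compounds:
Compound 1 (`O=C(NCc1ccc(S(=O)(=O)c2ccccc2)cc1)c1nc2ccncc2s1`): > 10000 nM, a limit
Compound 2 (`O=C(NCc1ccc(S(=O)(=O)N2CCCCC2)cc1)c1cc2cnccc2s1`): 1600 nM
Compound 3 (`Cn1c(C(=O)NCc2ccc(S(=O)(=O)c3ccccc3)cc2)cc2cnccc21`): > 10000 nM, a limit

For the measured compounds named here, in a functional assay on A2780 cells (Homo sapiens) for inhibition, read by sulforhodamine B assay, with a stated time of 72 h (on this read-out higher numbers stand for weaker inhibition and lower numbers for stronger inhibition), compound 2 is the only compound with a number rather than a limit. Compound 1 and compound 3 each stand at the limit of > 10000 nM in this assay, at which 2 of the 3 values shown sit.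

Compound 4 (`O=C(NCc1ccc(S(=O)(=O)N2CCCCC2)cc1)c1ccn2ccnc2c1`) has not yet been measured. Its difference from compound 2 is a group of 9 heavy atoms (7 carbon, 2 nitrogen; one five-membered aromatic ring with 2 hetero atoms, one six-membered aromatic ring with 1 hetero atom) in place of a group of 9 heavy atoms (7 carbon, 1 nitrogen, 1 sulfur; one five-membered aromatic ring with 1 hetero atom, one six-membered aromatic ring with 1 hetero atom), on a carbonyl carbon. No measured step sizes this change, so the expectation starts from compound 2 at 1600 nM in this assay. The expected move, a 2.5-fold higher number from compound 2 to compound 4 (0.40 log units; beyond the scatter), is toward weaker inhibition and modestly beyond the scatter. Compound 4 is estimated at 4000 nM, with an expected range from 600 nM to 10000 nM.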

Compound 4, half-maximal inhibitory concentration: > 10000 nM
Compound 4 was reported as a limit (the forecaster's own chance of this, stated with the estimate: 30%); middle value at least 2.5-fold (0.39 log units) from the limit.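

In this assay, exchanging the sulfur-containing group on the carbonyl carbon for the group with two nitrogens in its five-membered ring gives an at least 6.2-fold higher number from compound 2 to compound 4 (0.79 log units; beyond the scatter). The two groups have the same counts of hydrogen-bond donors and acceptors, so those counts alone do not preserve the inhibition at this place. Compound 4 is a limit, and it now stands with the other limits: the limit of > 10000 nM in this assay, at which 3 of the 4 values shown sit.

How far the true value of compound 4 lies past that limit cannot be read. As far as these compounds go, whether a single thiophene ring or a benzothiophene on the carbonyl carbon would retain the inhibition remains open.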